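Peptide series with ring-bound substituents: permeability notes

The source may hold more compounds than are shown below. What is called first, only, known or untested is meant among the compounds shown, and "the series" means these compounds.

Three compounds have been run in an ADME assay for permeability, using PAMPA; a lower number here means that the compound crosses the layer more slowly, a higher number that the compound crosses the layer faster. Going by the values given here, compound 1 `CCCCC(C(=O)OC)N1C(=O)/C(=C/c2ccc(C(=O)N[C@@H](CCCNC(=N)N)C(=O)N[C@@H](CCCCN)C(=O)N[C@@H](CCCC)C(N)=O)cc2)SC1=S` is the only member with a number: in this assay compound 1 gives 0.87 10^-6 cm/s. Compound 2 `CCCC[C@H](NC(=O)[C@H](CCCCN)NC(=O)[C@H](CCCNC(=N)N)NC(=O)c1ccc(/C=C2\NC(=S)N(c3ccccc3)C2=O)cc1)C(N)=O` gives "impermeable" (no number reported) in this assay, with no number reported. Compound 3 `CCCC[C@H](NC(=O)[C@H](CCCCN)NC(=O)[C@H](CCCNC(=N)N)NC(=O)c1cccs1)C(N)=O` likewise gives "impermeable" (no number reported) in this assay. Compound 1 therefore stands alone on the scale, with nothing numerical to rank it against. Compound 4 `CCCC[C@H](NC(=O)[C@H](CCCCN)NC(=O)[C@H](CCCNC(=N)N)NC(=O)c1ccc(/C=C2\SC(=S)N(C3CCCCC3)C2=O)cc1)C(N)=O` is not yet measured. It differs from compound 1 as follows: cyclohexyl in place of 1-(methoxycarbonyl)pentyl on an amide-type nitrogen in a ring. Among the compounds with values here, no step between measured compounds exists, so the step size is a guess; a change within the scatter or slightly downward is expected, a 1.5-fold lower number from compound 1 to compound 4 (0.16 log units; within the scatter). Compound 4 is expected to give 0.6 10^-6 cm/s, in the range 0.2 10^-6 cm/s to 1.5 10^-6 cm/s, because compound 1 at 0.87 10^-6 cm/s shares the same peptide part.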

Compound 4, apparent permeability: 1.82 10^-6 cm/s
Compound 4: middle estimate off by 3.0-fold (0.48 log units), on the low side; the whole stated range lies below it.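

In this assay, cyclohexyl in place of 1-(methoxycarbonyl)pentyl on the amide-type nitrogen in the ring gives a 2.1-fold higher number from compound 1 to compound 4 (0.32 log units; beyond the scatter). Going by these compounds alone, this is the only readable step, and it shows that the number shifts with the group at this position while the peptide part stays the same. No available data account for the size or direction of this step. A single step cannot separate the arrival of the ring from the loss of the methoxycarbonyl part. As far as these compounds go, an unbranched pentyl chain at this nitrogen would bear on that question, and how a carboxylic acid on that chain would read also stays open.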